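Removing a Methoxy Group on Two Different Cores

This account rests on a few compounds, and the source may have more. Where it says the series, first, only, none or still open, it means among the compounds named here.

Compound 1 `C=C(Br)C(=O)Nc1cccc(-c2cn3nc(Cc4cccc(OC)c4)sc3n2)c1`: 2000 nM
Compound 2 `C=C(Br)C(=O)Nc1cccc(-c2cn3nc(Cc4ccccc4)sc3n2)c1`: 3000 nM
Compound 3 `COc1ccc(-c2nn3cc(-c4cccc(N)c4)nc3s2)cc1OC`: 16000 nM

These numbers come from a functional assay on L1210 cells (Mus musculus) for inhibition, read by cell counting, with a stated time of 2 days; a lower number here means a stronger inhibitor, a higher number a weaker inhibitor. Compound 1 and compound 2 share one core; compound 2 differs from compound 1 by hydrogen in place of methoxy on an aromatic carbon. That change gave a 1.5-fold higher number from compound 1 to compound 2 (0.18 log units; within the scatter). Compound 3 has a different core, and the difference between the two cores is not broken down here. Compound 4 `COc1ccc(-c2nn3cc(-c4cccc(N)c4)nc3s2)cc1` differs from compound 3 by hydrogen in place of methoxy on an aromatic carbon. The surroundings are not identical: in compound 3 the leaving methoxy is ortho to a methoxy group and meta to a large group, while in compound 1 it is only meta to a large group, so this is the same kind of change, not the same one. Resting on the step of a 1.5-fold higher number from compound 1 to compound 2 (0.18 log units; within the scatter), compound 4 is expected to stay close to compound 3, with an estimated 1.3-fold higher number from compound 3 to compound 4 (0.10 log units; within the scatter). Compound 4 is estimated at 20000 nM, between 8000 nM and 50000 nM.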

Compound 4, half-maximal inhibitory concentration: >= 250000 nM
Compound 4: a limit, no number (the forecaster's own chance of this, stated with the estimate: 10%); middle value at least 12-fold (1.09 log units) away from the limit.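

Removing the methoxy group gave an at least 15-fold higher number from compound 3 to compound 4 (1.19 log units; beyond the scatter) in this assay, so the size of this change did not carry over from one core to the other: the same change on two cores in this assay, a 1.5-fold higher number (0.18 log units; within the scatter) from compound 1 to compound 2 and an at least 15-fold higher number (1.19 log units; beyond the scatter) from compound 3 to compound 4, at least 10-fold (1.01 log units) apart, beyond the scatter of two such steps. Compound 4 gives >= 250000 nM, and this is a limit of the assay, not a number: the limit of >= 250000 nM in this assay, at which 1 of the 4 values shown sits. What lies behind the gap stays unknown, as the two compounds being changed differ in their cores and the leaving methoxy group in compound 3 is also ortho to a methoxy group.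

The compounds shown leave open whether the core or that neighbouring methoxy group matters more. On these data alone, it also remains open whether a hydroxyl group or a chlorine atom in the same place would keep the number close to that of compound 3.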